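Three weak analogues and a thiourea with a bromine swap

This account rests on a few compounds, and the source may have more. Where it says the series, first, only, none or still open, it means among the compounds named here.

Measured so far:
compound 1, `N#Cc1ccccc1CN1CCc2c(sc(NC(=O)c3ccccc3Cl)c2C(N)=O)C1`, 9500 nM;
compound 2, `NC(=O)c1c(NC(=O)c2ccccc2Cl)sc2c1CCN(C(=S)Nc1cccc3ccccc13)C2`, 20700 nM;
compound 3, `NC(=O)c1c(NC(=O)c2ccccc2Cl)sc2c1CCN(C(=O)Nc1ccccc1Cl)C2`, 16300 nM.

All three compounds share one core and were tested in a functional assay on MKN-74 cells (Homo sapiens) for antiproliferative activity, with a stated time of 24 h; on this read-out lower numbers stand for stronger inhibition and higher numbers for weaker inhibition. Compound 3 sits second highest of the three numbers, but every gap around it is small: the step of a 1.7-fold higher number from compound 1 to compound 3 (0.23 log units; within the scatter) lies within the scatter, and the values of compound 3 and compound 2 are also within the scatter of each other, so no ordering among the three can be claimed.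

Compound 4, `NC(=O)c1c(NC(=O)c2ccccc2Cl)sc2c1CCN(C(=S)Nc1ccccc1Br)C2`, differs from compound 3 in one place: a group of 10 heavy atoms (7 carbon, 1 nitrogen, 1 sulfur, 1 bromine; one six-membered aromatic ring of carbon only) in place of a group of 10 heavy atoms (7 carbon, 1 nitrogen, 1 oxygen, 1 chlorine; one six-membered aromatic ring of carbon only), on an amine nitrogen in a ring. Within the data shown here, only the step from compound 1 to compound 3 touches this position, and it was within the scatter; compound 2 carries a related sulfur-bearing group there and gives a number close to that of compound 3. Nothing here points to a shift beyond the scatter. Compound 4 is therefore expected to give roughly 18000 nM in this assay, with a range of 8000 nM to 40000 nM. The expected step of a 1.1-fold higher number from compound 3 to compound 4 (0.04 log units; within the scatter) is estimated to fall within the scatter.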

Compound 4, half-maximal inhibitory concentration: 10800 nM
Compound 4: the middle estimate sits 1.7-fold (0.22 log units) above what was measured, and the stated range covers the measured number.
By their numbers in this assay, from the lowest: compounds 1, 4, 3 and 2 (each within the scatter of the next, the first and the last beyond it).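

In this assay, compound 4 exchanges both the oxygen for sulfur and the chlorine for bromine in a single step, and a 1.5-fold lower number from compound 3 to compound 4 (0.18 log units; within the scatter) shows that this double exchange on the amine nitrogen in a ring does not move the number beyond the scatter. The two other comparisons agree: a 1.9-fold lower number from compound 2 to compound 4 (0.28 log units; within the scatter) comes with 2-bromophenyl in place of naphthalen-1-yl, and a 1.1-fold higher number from compound 1 to compound 4 (0.06 log units; within the scatter) comes with the new group in place of 2-cyanobenzyl, so compound 4 cannot be separated from any of the other three. Nothing measured here explains these numbers.

As far as these compounds go, since both exchanges occur together, the contribution of each one alone remains open. From the compounds shown here alone, it is also open whether a carboxylic acid or an amine on the phenyl ring, or a small methyl on the ring nitrogen, would shift the number beyond the scatter.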